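The compounds below may be only part of what the source reports. "The series", "measured", "known", "first", "only" and "open" are said of these compounds alone.

Working notes on the series, read in a functional assay on SGC-7901 cells (Homo sapiens), read by wound healing assay, with a stated time of 48 h; on this read-out lower numbers stand for stronger inhibition and higher numbers for weaker inhibition. Compound 1 `C=C1CC[C@@H]2[C@](C)(CO)[C@H](O)CC[C@@]2(C)[C@@H]1/C=C/C1=C/C(=C/c2ccc(Cl)cc2)OC1=O` gives 4300 nM, and compound 2 `C=C1CC[C@@H]2[C@](C)(CO)[C@H](O)CC[C@@]2(C)[C@@H]1/C=C/C1=C/C(=C/c2ccc(F)cc2)OC1=O` gives 8000 nM. Within the data shown here, these are the only two numbers so far, and compound 2 stands within the scatter of compound 1, so no order can be read between them.

The next change leads to compound 3 `C=C1CC[C@@H]2[C@](C)(CO)[C@H](O)CC[C@@]2(C)[C@@H]1/C=C/C1=C/C(=C/c2ccc(Br)cc2)OC1=O`, which is compound 2 with one substituent exchanged: bromo in place of fluoro on an aromatic carbon. In words, this is bromo in place of fluoro on an aromatic carbon, or 4-fluorophenyl to 4-bromophenyl. Among the measured compounds shown here, no bromo compound has a number yet. For the measured compounds named here, the one measured step that bears on this exchange swaps one halogen for another on the same aromatic carbon, and it reads a 1.9-fold higher number from compound 1 to compound 2 (0.27 log units; within the scatter). As that step stays within the scatter, no step beyond the scatter is expected in this assay here, and any direction remains tentative. The expected change is a 1.6-fold lower number from compound 2 to compound 3 (0.20 log units; within the scatter). Compound 3 is expected at 5000 nM, with an estimated range of 2000 nM to 12000 nM.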

Compound 3, half-maximal inhibitory concentration: 8600 nM
Compound 3: the middle estimate sits 1.7-fold (0.24 log units) below what was measured, and the stated range covers the measured number.
By their numbers in this assay, from the lowest: compounds 1, 2 and 3 (each within the scatter of the next).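

In this assay the exchange of fluoro for bromo on the aromatic carbon gives a 1.1-fold higher number from compound 2 to compound 3 (0.03 log units; within the scatter) and the exchange of chloro for bromo gives a 2.0-fold higher number from compound 1 to compound 3 (0.30 log units; within the scatter) and so chloro, fluoro and bromo all read within the scatter of one another at this place. The earlier pair covered only chloro and fluoro; with bromo added, the three compounds still give no order among the halogens, and none of them separates from the other two on this read-out. Nothing on hand offers an explanation for this flat reading.

Going by these compounds, whether any group other than a halogen at this place, such as methoxy, an amine or a carboxylic acid, would produce a step beyond the scatter remains open, and so does the reading of a phenyl ring with no substituent at all. Also open, on these data alone, is whether the same flat reading would hold with a halogen on another carbon of that six-membered aromatic ring, or with changes elsewhere on the shared core.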